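This account rests on a few compounds, and the source may have more. Where it says the series, first, only, none or still open, it means among the compounds named here.

Of the compounds shown here, three of a shared core have been measured in an assay for positive allosteric modulation of metabotropic glutamate receptor 3 (Rattus norvegicus); on this read-out lower numbers stand for an effect already at smaller amounts and higher numbers for an effect only at larger amounts of compound. Compound 1 `Cc1c(OCCCCOc2cncc(C(=O)O)c2)ccc(C(=O)CC(C)(C)C)c1O` gives 180 nM, the lowest of the three numbers. Compound 2 `CNC(=O)c1cc(OCCCCOc2ccc(C(=O)CC(C)(C)C)c(O)c2C)ccc1F` gives 476 nM, and compound 3 `COc1cc(OCCCCOc2ccc(C(=O)CC(C)(C)C)c(O)c2C)cc(C(=O)O)c1` gives 703 nM; both of these stand beyond the usual scatter from compound 1, so compound 1 is the strongest of the three on this read-out.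

Compound 4 `Cc1ccc(C(=O)O)cc1OCCCCOc1ccc(C(=O)CC(C)(C)C)c(O)c1C` has not yet been measured. It differs from compound 1 in one place: 5-carboxy-2-methylphenyl in place of 5-carboxypyridin-3-yl on an oxygen on a saturated carbon. The rest of the molecule, the long chain with its oxygens and the ketone-bearing ring at the other end, is kept as it is. Going by the values given here, no measured pair in this set shows the effect of exactly this change, so the direction of the step has to be estimated rather than read off. A modest weakening is expected, on the order of what is seen from compound 1 to compound 2, giving an expected step of a 1.8-fold higher number from compound 1 to compound 4 (0.25 log units; within the scatter) in this assay. Compound 4 is therefore estimated at 320 nM, within a range from 120 nM to 850 nM.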

Compound 4, half-maximal effective concentration: 892 nM
Beside the measured number, compound 4's estimate is 2.8-fold (0.45 log units) below it; the measured number lies above the stated range.
By their numbers in this assay, from the lowest: compound 1; then compounds 2, 3 and 4 (each within the scatter of the next).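

Replacing 5-carboxypyridin-3-yl with 5-carboxy-2-methylphenyl on this oxygen gives a 5.0-fold higher number from compound 1 to compound 4 (0.70 log units; beyond the scatter) in this assay, so a carboxylic acid on the ring does not by itself keep the number low. Compound 1, the only one of the four with a nitrogen in this ring, now stands lowest, beyond the scatter from each of the compounds with a carbon-only ring. Nothing available here explains this step.

The change removes the ring nitrogen and adds a methyl in a single step, so the part played by each remains unresolved, and a plain 5-carboxyphenyl group, with neither feature, would be needed to separate them. Also open, from the compounds shown here alone, is how the 5-carboxypyridin-3-yl ring would read with an amine in place of its carboxylic acid.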